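The compounds below may be only part of what the source reports. "The series", "measured", "known", "first", "only" and "open" are said of these compounds alone.

Among the measured compounds shown here, compound 2 `COc1ccc(-n2nc(Sc3ccc(Cl)cc3)cc(CC[C@@H](C)NC(=O)[C@H]3CNCC[C@@H]3c3ccc(Cl)cc3Cl)c2=O)cc1` stands lowest of the two numbers so far: in an assay on CHO cells for binding affinity to Melanocortin receptor 4 (Homo sapiens) (on this read-out lower numbers stand for stronger inhibition and higher numbers for weaker inhibition), compound 2 gives 3.2 nM, while compound 1 `COc1ccc(-n2nc(Sc3ccc(Cl)cc3)cc(CC[C@@H](C)NC(=O)[C@H]3CNCC[C@@H]3c3cccc(Cl)c3)c2=O)cc1` gives 43 nM. Compound 3 `COc1ccc(-n2nc(Sc3ccc(Cl)cc3)cc(CC[C@@H](C)NC(=O)[C@H]3CNCC[C@@H]3c3cccc(F)c3)c2=O)cc1` carries 3-fluorophenyl in place of 2,4-dichlorophenyl on a saturated ring carbon, so it holds 3-fluorophenyl where compound 1 held 3-chlorophenyl. For the measured compounds named here, the only measured step bearing on this is a 13-fold lower number from compound 1 to compound 2 (1.13 log units; beyond the scatter), a large gain on moving to 2,4-dichlorophenyl. Undoing that change is expected to cost most of the gain, so the step of a 19-fold higher number from compound 2 to compound 3 (1.27 log units; beyond the scatter) is expected. Compound 3 is therefore estimated at 60 nM in this assay, with a range from 18 nM to 200 nM.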

Compound 3, half-maximal inhibitory concentration: 490 nM
Compound 3: the middle estimate sits 8.2-fold (0.91 log units) below what was measured; measured number above the stated range.
By their numbers in this assay, from the lowest: compound 2; then compound 1; then compound 3.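

In this assay, exchanging chloro for fluoro alone gives an 11-fold higher number from compound 1 to compound 3 (1.06 log units; beyond the scatter), so this position responds to a single halogen swap and not only to the move to 2,4-dichlorophenyl. The span at this saturated ring carbon, a 150-fold higher number from compound 2 to compound 3 (2.19 log units; beyond the scatter), is wider than either single step from compound 1, and the three aryl groups fall in the order 2,4-dichlorophenyl, 3-chlorophenyl, 3-fluorophenyl. No measurement shown here accounts for the size of these steps.

The compounds shown leave open how an unsubstituted phenyl or a methoxyphenyl would read at this carbon. They also leave open whether the low number of compound 2 rests on one chlorine or on both.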